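The source may hold more compounds than are shown below. What is called first, only, known or untested is meant among the compounds shown, and "the series" means these compounds.

In a functional assay on COLO 205 cells (Homo sapiens) for cytotoxicity, read by MTT assay, with a stated time of 72 h (on this read-out higher numbers stand for weaker inhibition and lower numbers for stronger inhibition), compound 1 `COc1ccc(/C=C/C(=O)Nc2cc(C(=O)c3cc(OC)c(OC)c(OC)c3)ccc2OC)cc1` gives 10900 nM. Compound 2 `COc1cc(/C=C/C(=O)Nc2cc(C(=O)c3cc(OC)c(OC)c(OC)c3)ccc2OC)ccc1F` gives 11800 nM in this assay, and the two numbers cannot be told apart, since the step of a 1.1-fold higher number from compound 1 to compound 2 (0.03 log units; within the scatter) stays within the scatter. Compound 3 `COc1ccc(C(=O)c2cc(OC)c(OC)c(OC)c2)cc1NC(=O)/C=C/c1cccc(OC(F)(F)F)c1` differs from compound 2 in one place: 3-(trifluoromethoxy)phenyl in place of 4-fluoro-3-methoxyphenyl on a double-bonded chain carbon bound to a double-bonded chain carbon. Within the data shown here, the only measured step also exchanged one group on this chain carbon and did not leave the scatter, so a step of a 1.0-fold higher number from compound 2 to compound 3 (0.01 log units; within the scatter) is expected here, with no change beyond the scatter. Compound 3 is therefore estimated at 12000 nM, within a range from 5000 nM to 30000 nM.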

Compound 3, half-maximal inhibitory concentration: 7900 nM
Compound 3: middle estimate off by 1.5-fold (0.18 log units), on the high side; the measured number falls inside the stated range.
By their numbers in this assay, from the lowest: compounds 3, 1 and 2 (each within the scatter of the next).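

In this assay, a third group on this chain carbon still gives no change beyond the scatter, both for a 1.5-fold lower number from compound 2 to compound 3 (0.17 log units; within the scatter) and for a 1.4-fold lower number from compound 1 to compound 3 (0.14 log units; within the scatter), so 3-(trifluoromethoxy)phenyl cannot be told apart from either earlier group. Across compounds 1, 2 and 3, this position has therefore taken three different substituted phenyl groups with no measurable difference. No measurement is available that could explain this result. Still open, on these data alone, is whether a longer chain at this chain carbon, or a phenyl carrying an amine or a carboxylic acid, would move the number beyond the scatter.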